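Carbonyl with fluorines in place of a thiocarbamate

The source may report more compounds than this note shows. Statements on the series, on what has been measured and on what is new or still open speak of the compounds shown alone.

Compound 1 `Cc1nc(S(C)(=O)=O)ccc1Oc1ncnc(OC2CCN(C(=O)O[C@H](C)C(F)(F)F)CC2)c1F` gives in a functional assay on isolated protein for inhibition of Glucose-dependent insulinotropic receptor (Rattus norvegicus), read by HTRF and cAMP accumulation (a lower number here means a smaller maximal response, a higher number a larger maximal response), a value of 85%
Compound 2 `Cc1nc(S(C)(=O)=O)ccc1Oc1ncnc(OC2CCN(C(=S)OC(C)C)CC2)c1F` gives in this assay a value of 47%
Compound 3 `Cc1nc(S(C)(=O)=O)ccc1Oc1ncnc(OC2CCN(C(=S)OC3(C)CC3)CC2)c1F` gives in this assay a value of 49%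

Compound 3 stands second highest of the three numbers in this assay; its value and that of compound 2 lie within the scatter of each other, while compound 1 stands far above it, as a number 36 percentage points lower from compound 1 to compound 3 (beyond the scatter) shows. Compound 4 `CCC(F)(F)C(=O)N1CCC(Oc2ncnc(Oc3ccc(S(C)(=O)=O)nc3C)c2F)CC1` differs from compound 3 in one place: a group of 7 heavy atoms (4 carbon, 1 oxygen, 2 fluorine; no ring) in place of a group of 7 heavy atoms (5 carbon, 1 oxygen, 1 sulfur; one three-membered non-aromatic ring of carbon only), on an amine nitrogen in a ring.

Going by the values given here, two measured steps bear on this change. Both a number 38 percentage points lower from compound 1 to compound 2 (beyond the scatter) and a number 36 percentage points lower from compound 1 to compound 3 (beyond the scatter) describe the move from a carbonyl-bearing group with fluorine to a thiocarbonyl-bearing group on the same amine nitrogen, and both were large downward. The step from compound 3 to compound 4 runs the other way, reintroducing a carbonyl and fluorine atoms while removing the thiocarbonyl. Compound 4 is therefore expected to climb back toward compound 1, with an estimated a number 26 percentage points higher from compound 3 to compound 4 (beyond the scatter), because a number 36 percentage points lower from compound 1 to compound 3 (beyond the scatter) marks the same shift in reverse. For compound 4 the estimate in this assay is 75%, within a range from 55% to 92%.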

Compound 4, largest response reached (reported as efficacy), in percent of the reference or control that the assay uses: 90%
For compound 4 the middle estimate is 15 percentage points below the measured one; the range from low to high includes it.
By their numbers in this assay, from the lowest: compounds 2 and 3 (each within the scatter of the next); then compounds 1 and 4 (each within the scatter of the next).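

Compound 4 shows that the oxygen-linked 1-(trifluoromethyl)ethoxy is not needed on the carbonyl carbon to hold the maximal response: with 1,1-difluoropropyl in its place, a number 5 percentage points higher from compound 1 to compound 4 (within the scatter) in this assay and the two compounds stay level. The thiocarbonyl compounds now sit apart from two different carbonyl groups, not just one, with a number 41 percentage points higher from compound 3 to compound 4 (beyond the scatter) and a number 43 percentage points higher from compound 2 to compound 4 (beyond the scatter) as large steps in this assay for this change on the amine nitrogen. Nothing available explains why the response differs in this way.

Compound 4 differs from compounds 2 and 3 in both the thiocarbonyl and the fluorines, so the shown compounds do not tell these two apart. Plain propyl on the carbonyl carbon would bear on that question, and how far a longer chain such as 1,1-difluorobutyl is tolerated remains open.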